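This account rests on a few compounds, and the source may have more. Where it says the series, first, only, none or still open, it means among the compounds named here.

Measured so far, in a functional assay on Jurkat cells (Homo sapiens) for antiproliferative activity, read by WST assay, with a stated time of 72 h; a higher number here means a weaker inhibitor, a lower number a stronger inhibitor:
Compound 1 `Cc1noc(-c2cc3ccccc3[nH]2)n1` gives > 50000 nM, which is a limit of this assay rather than a number.
Compound 2 `c1ccc(-c2noc(-c3cc4ccccc4[nH]3)n2)cc1` gives > 50000 nM, again a limit.
Compound 3 `Oc1ccc2[nH]c(-c3nc(-c4ccccc4)no3)cc2c1` gives 26900 nM.

Compound 2 therefore stands at the edge of what this assay can report, sharing the limit of > 50000 nM in this assay, at which 2 of the 3 values shown sit, with compound 1. Compound 4 `COc1ccc(-c2noc(-c3cc4ccccc4[nH]3)n2)cc1` differs from it by methoxy in place of hydrogen on an aromatic carbon. Among the measured compounds shown here, only one measured step resembles this one: an at least 1.8-fold lower number from compound 2 to compound 3 (0.26 log units; that floor lies within the scatter), where the added group sat on the shared core rather than on the phenyl, and even that gain was small. A methoxy on the phenyl is expected to leave compound 4 near the limit, so a number no higher from compound 2 to compound 4 (the limit leaves the size open) is estimated as no step beyond the scatter. Compound 4 is thus expected at 50000 nM, with a range from 15000 nM to 150000 nM.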

Compound 4, half-maximal inhibitory concentration: > 50000 nM
Compound 4 gave a limit, no number; the forecaster's own chance of this, stated with the estimate: 70%; the middle value sits exactly at the limit.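

No step can be read from compound 2 to compound 4, as both compounds give a limit rather than a number: the limit of > 50000 nM in this assay, at which 3 of the 4 values shown sit. The compounds shown leave open whether methoxy in place of hydrogen changes activity at all.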